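Swapping the chain on the aryl ether of compound 3

The source may report more compounds than this note shows. Statements on the series, on what has been measured and on what is new or still open speak of the compounds shown alone.

Compound 3 `CC(C)=CCOc1cccc2ccc(N)nc12` carries a 3-methylbut-2-en-1-yl on an oxygen on an aromatic ring of the shared core. In an assay on cells with melanin-concentrating hormone receptor 1 (Homo sapiens) as the target, read by radioligand binding (on this read-out lower numbers stand for stronger inhibition and higher numbers for weaker inhibition), compound 3 gives > 2000 nM, which is a limit of the assay rather than a number. Compound 1 `CC1CCC(Oc2cccc3ccc(N)nc23)C1`, with 3-methylcyclopentyl in that place, gives 823 nM in this assay. Compound 2 `Nc1ccc2cccc(OCC3CCCO3)c2n1`, with (oxolan-2-yl)methyl there, gives > 2000 nM in this assay, again a limit. The step of an at least 2.4-fold higher number from compound 1 to compound 3 (0.38 log units; beyond the scatter) and the step of an at least 2.4-fold higher number from compound 1 to compound 2 (0.38 log units; beyond the scatter) both end at the limit, and the step that the two limits leave unreadable from compound 2 to compound 3 cannot be sized because both of its ends sit at the limit of > 2000 nM in this assay, at which 2 of the 3 values shown sit.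

Compound 4 `CC(C)OCCOc1cccc2ccc(N)nc12` differs from compound 3 by isopropoxymethyl in place of 2-methylprop-1-en-1-yl on a saturated chain carbon bound to an oxygen on an aromatic ring. The step from compound 1 to compound 2 is the one that bears most on this change, since compound 2 also holds an oxygen within the chain on the same oxygen on the aromatic ring, and it stayed at the limit. Among the compounds with values here, nothing among the measured compounds suggests that the new chain would pull compound 4 back toward the number of compound 1. Compound 4 is therefore expected to show a step that the limit leaves unreadable from compound 3 to compound 4, most likely another limit. The estimate for compound 4 is 3000 nM in this assay, with a range from 800 nM to 12000 nM.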

Compound 4, half-maximal inhibitory concentration: > 2000 nM
Compound 4 gave a limit, no number (the forecaster's own chance of this, stated with the estimate: 70%); the middle value lies beyond the limit too.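

Putting 2-isopropoxyethyl in place of 3-methylcyclopentyl on the oxygen on the aromatic ring gives an at least 2.4-fold higher number from compound 1 to compound 4 (0.38 log units; beyond the scatter) in this assay, so a third chain now fails to match compound 1. The three chains that replace 3-methylcyclopentyl differ from one another, as an open chain with a double bond, an open chain with an ether oxygen and an oxolane ring, yet none of them gives a readable number in this assay, and compound 1 remains the only one of the four with a value that is not a limit. The steps among compound 2, compound 3 and compound 4 cannot be read, so the swap of 2-methylprop-1-en-1-yl for isopropoxymethyl has no measurable size, and the result only widens the group of chains that end at the same limit: the limit of > 2000 nM in this assay, at which 3 of the 4 values shown sit.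

The compounds shown leave open whether the number of compound 1 depends on the ring, on its methyl group or on both, which an unsubstituted cyclopentyl or a cyclohexyl on the same oxygen would address. They also leave open how a chain ending in an amine, such as 2-(dimethylamino)ethyl, would read at this position.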